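Configuration change at two ring carbons in the series

The source may report more compounds than this note shows. Statements on the series, on what has been measured and on what is new or still open speak of the compounds shown alone.

In a functional assay on HeLa cells (Homo sapiens) for cytotoxicity, read by WST assay, with a stated time of 48 h (on this read-out higher numbers stand for weaker inhibition and lower numbers for stronger inhibition), three compounds of the series have been measured. Compound 1 `COc1cccc([C@@H]2OC[C@H]([C@@H](O)c3ccc(OC)c(OC)c3)C[C@H]2C/C=C/c2ccc(OC)c(OC)c2)c1` gives 30100 nM, compound 2 `COc1ccc([C@@H]2OC[C@H]([C@@H](O)c3ccc(OC)c(OC)c3)C[C@H]2C/C=C/c2ccc(OC)c(OC)c2)cc1` gives 29200 nM, and compound 3 `COc1ccc(/C=C/C[C@H]2C[C@@H]([C@@H](O)c3ccc(OC)c(OC)c3)CO[C@@H]2c2ccccc2)cc1OC` gives 17000 nM. The number for compound 3 therefore lies within the scatter of both others, and the three values cannot be ranked.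

Compound 4 `COc1ccc(/C=C/C[C@@H]2C[C@@H]([C@@H](O)c3ccc(OC)c(OC)c3)CO[C@H]2c2ccccc2)cc1OC` has the same atoms and bonds as compound 3 and differs only in configuration as drawn: the two compounds have the same atoms and bonds and differ only in configuration as drawn: 2 of 5 stereo elements differ; a stereocentre at a saturated ring carbon is drawn S in compound 3 and R in compound 4; a stereocentre at a saturated ring carbon is drawn S in compound 3 and R in compound 4. A stereocentre at a saturated ring carbon is drawn S in compound 3 and R in compound 4, and this holds at both changed centres.

Among the compounds with values here, no measured pair differs in configuration, so no step speaks directly to this change. Within the data shown here, the only measured step, a 1.0-fold lower number from compound 1 to compound 2 (0.01 log units; within the scatter), is a swap of 3-methoxyphenyl for 4-methoxyphenyl and bears on it only indirectly. Among the measured compounds shown here, it shows a flat series so far, but says nothing about configuration, so the range has to stay wide on both sides. No direction can be argued from these data, and the expected change is a 1.1-fold higher number from compound 3 to compound 4 (0.02 log units; within the scatter), which is no step beyond the scatter. For compound 4 the estimated value in this assay is 18000 nM, with an expected range of 7000 nM to 45000 nM.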

Compound 4, half-maximal inhibitory concentration: 16100 nM
For compound 4 the middle estimate is 1.1-fold (0.05 log units) above the measured one; the measured number falls inside the stated range.
By their numbers in this assay, from the lowest: compounds 4, 3, 2 and 1 (each within the scatter of the next).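

In this assay, inverting both ring carbons gives a 1.1-fold lower number from compound 3 to compound 4 (0.02 log units; within the scatter), so the first configuration change seen in the series leaves the number within the scatter, and the drawn configuration at these two centres shows no readable effect on the HeLa read-out. Hydrogen in place of methoxy on an aromatic carbon gives a 1.8-fold lower number from compound 2 to compound 4 (0.26 log units; within the scatter) and a 1.9-fold lower number from compound 1 to compound 4 (0.27 log units; within the scatter), so neither the 4-methoxyphenyl nor the 3-methoxyphenyl comparison separates from compound 4, and all four compounds remain unranked. The step from the configuration change can be read as a test of configuration alone, with no group change mixed in, because of one fact: the fact that compounds 3 and 4 differ only in the configuration as drawn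

Within the data shown here, still open is how inversion at only one of the two ring carbons would read in this assay, since the two changes here appear together and any opposing contributions could cancel. Also open is whether an amine or a carboxylic acid in place of methoxy on that aromatic carbon would move the number beyond the scatter, which the methoxy and hydrogen compounds shown cannot indicate.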